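Vinylcarbonyl to Vinylsulfonyl on the Amine Nitrogen

A few compounds are considered here, and "the series" means these few. Any claim that something is new, unique, unknown or untested is made for them only; others in the source may bear on it.

Of the compounds shown here, three of one series have been measured in a functional assay on MV4-11 cells (Homo sapiens) for antiproliferative activity, read by luminescence, with a stated time of 72 h; a lower number here means a stronger inhibitor, a higher number a weaker inhibitor. Compound 1, `C/C=C/C(=O)NC/C=C/c1cc(OCCc2ccc(F)cc2)cc(O)c1C(=O)OC(C)C`, reaches only the limit of the assay, giving > 10000 nM. Compound 2, `C=CC(=O)NC/C=C/c1cc(OC)cc(O)c1C(=O)OC(C)C`, likewise sits at the limit, giving > 10000 nM. For the measured compounds named here, compound 3, `COc1cc(O)c(C(=O)OCC(C)c2ccccc2)c(/C=C/CN2C(=O)C=CC2=O)c1`, is the one member with a number, giving 3380 nM in this assay. Compound 2 therefore stands among the weaker members of the set: the limit of > 10000 nM in this assay, at which 2 of the 3 values shown sit, so its result is a boundary rather than a number, and only compound 3 offers a measured point of reference.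

The step followed here leads to compound 4, `C=CS(=O)(=O)NC/C=C/c1cc(OC)cc(O)c1C(=O)OC(C)C`, which has not yet been measured. The change is vinylsulfonyl in place of vinylcarbonyl on an amine nitrogen. Going by the values given here, no step between two measured compounds carries this same change, so the expected size rests on the structural difference alone. Since compound 2 gives > 10000 nM as a limit, any outcome for compound 4 that is no stronger would again be reported as a limit, and a gain would have to be considerable before a number appeared.

Compound 4 is expected at about 10000 nM, in a range from 2500 nM to 40000 nM. The step is estimated as a number no higher from compound 2 to compound 4 (the limit leaves the size open), which is expected to lie within the scatter of the assay.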

Compound 4, half-maximal inhibitory concentration: 4660 nM
Estimate against measurement, compound 4: 2.1-fold (0.33 log units) above; the measured number falls inside the stated range.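

In this assay, for the compounds shown here, vinylsulfonyl in place of vinylcarbonyl on this amine nitrogen gives an at least 2.1-fold lower number from compound 2 to compound 4 (0.33 log units; beyond the scatter), the first step that can be read at all, and it shows that this one change on the nitrogen is enough to bring a measurable number where the vinylcarbonyl compound gave none. Going by these compounds alone, the true size of the step stays open on one side, since the starting point of compound 2 is a limit of the assay and not a number: the limit of > 10000 nM in this assay, at which 2 of the 4 values shown sit. Compound 3, the only earlier compound with a number, differs from compound 4 in more than one place, so the two cannot be set against each other as a step, and no measured property of either group is at hand to explain the gain.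

The compounds shown hold no second pair with this change, so whether it carries over to a core with a larger ether or ester group, as in compound 1 or compound 3, remains open. Also open, going by these compounds, is what an ethylsulfonyl group, without the vinyl double bond, would give on the same nitrogen, and with it whether the sulfonyl or the vinyl part matters.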